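A Basic Side Chain Replaces Methylsulfonyl

A few compounds are considered here, and "the series" means these few. Any claim that something is new, unique, unknown or untested is made for them only; others in the source may bear on it.

Compound 1 `CCOC(=O)N1CCN(c2ccc3nnc(-c4cccc(C)c4)n3n2)CC1`: 1 ug/mL
Compound 2 `CC(=O)N1CCN(c2ccc3nnc(-c4cccc(C)c4)n3n2)CC1`: 28.6 ug/mL
Compound 3 `Cc1cccc(-c2nnc3ccc(N4CCN(S(C)(=O)=O)CC4)nn23)c1`: 10.8 ug/mL

These three compounds share one core and differ only in the group on one ring nitrogen. All were tested in a functional assay for inhibition, read by spectrophotometry, with a stated time of 60 min; a higher number here means a weaker inhibitor, a lower number a stronger inhibitor. Compound 3 , at 10.8 ug/mL, holds the second highest of the three numbers, so it sits in the middle of this small set. The next compound keeps the core but changes that group again. In compound 4 `Cc1cccc(-c2nnc3ccc(N4CCN(CCN)CC4)nn23)c1`, 2-aminoethyl stands in place of methylsulfonyl on an amine nitrogen in a ring: 2-aminoethyl in place of methylsulfonyl on an amine nitrogen in a ring.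

Going by the values given here, three measured steps concern this same nitrogen. Two are large: a 29-fold higher number from compound 1 to compound 2 (1.46 log units; beyond the scatter) and an 11-fold higher number from compound 1 to compound 3 (1.03 log units; beyond the scatter). The third is modest: a 2.6-fold lower number from compound 2 to compound 3 (0.42 log units; beyond the scatter). Changes at this position can therefore shift the number considerably. However, none of the measured compounds carries a 2-aminoethyl group, so these steps show the possible size of a change better than its direction. Only a small move towards a higher number in this assay is expected, possibly none beyond the scatter, and the uncertainty is wide. The expected step is a 1.4-fold higher number from compound 3 to compound 4 (0.14 log units; within the scatter). For compound 4 the estimated value is 15 ug/mL, with an expected range from 4 ug/mL to 55 ug/mL.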

Compound 4, half-maximal inhibitory concentration: 25.4 ug/mL
For compound 4 the middle estimate is 1.7-fold (0.23 log units) below the measured one; the measured number falls inside the stated range.
By their numbers in this assay, from the lowest: compound 1; then compound 3; then compounds 4 and 2 (each within the scatter of the next).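

In this assay, going by these compounds alone, a 2.4-fold higher number from compound 3 to compound 4 (0.37 log units; beyond the scatter) shows that on this ring nitrogen a 2-aminoethyl group, the only group here with neither a carbonyl nor a sulfonyl attached to that nitrogen, gives a weaker inhibitor than methylsulfonyl does. The same chain cannot be told apart from acetyl, with a 1.1-fold lower number from compound 2 to compound 4 (0.05 log units; within the scatter) lying within the usual scatter, so two quite different groups give the same level of inhibition at this position, while ethoxycarbonyl stays well ahead of the new group, with a 25-fold higher number from compound 1 to compound 4 (1.40 log units; beyond the scatter) marking a large gap. Nothing available here explains why these groups rank as they do.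

The compounds shown leave open whether the lead of compound 1 depends on the ethoxy part of its group, which a methoxycarbonyl or a butoxycarbonyl group on the same nitrogen would help to test. They also leave open whether the amine chain is tied to its present length and end, as a longer 3-aminopropyl chain or a chain ending in a dimethylamino group or a carboxylic acid could show.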